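Compound 2 to compound 3: pyridin-2-yl leaves the oxygen

The source may report more compounds than this note shows. Statements on the series, on what has been measured and on what is new or still open speak of the compounds shown alone.

- Compound 1 `CC(C)(C)C#Cc1cc(N(C(=O)[C@H]2CC[C@H](C)CC2)[C@H]2C[C@@H](Oc3cccnc3)C2)c(C(=O)O)s1`: > 20000 nM (a limit)
- Compound 2 `CC(C)(C)C#Cc1cc(N(C(=O)[C@H]2CC[C@H](C)CC2)[C@H]2CC[C@H](Oc3ccccn3)CC2)c(C(=O)O)s1`: > 20000 nM (a limit)

Both entries are limits in an ADME assay on MT4 cells (Homo sapiens) for cytotoxicity, with a stated time of 5 days (a lower number here means that less compound is tolerated, a higher number that more compound is tolerated), not numbers: the limit of > 20000 nM in this assay, at which 2 of the 2 values shown sit. In this assay compound 2 gives > 20000 nM, which is a limit.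

Compound 3 `CC(C)(C)C#Cc1cc(N(C(=O)[C@H]2CC[C@H](C)CC2)[C@H]2CC[C@H](O)CC2)c(C(=O)O)s1` carries hydrogen in place of pyridin-2-yl on an oxygen on a saturated carbon, (pyridin-2-yl)oxy to hydroxy: hydrogen in place of pyridin-2-yl on an oxygen on a saturated carbon. Going by the values given here, no measured step covers this change, so the expectation rests only on the limit of compound 2, > 20000 nM.

In this assay no change beyond the scatter is expected, an estimated step that the limit leaves unreadable from compound 2 to compound 3. Compound 3 is estimated at 25000 nM, with an expected range of 12000 nM to 60000 nM.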

Compound 3, half-maximal cytotoxic concentration: > 20000 nM
Compound 3 ended at the assay's limit; the forecaster's own chance of this, stated with the estimate: 80%; the middle value does not contradict the limit.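

In this assay, going by these compounds alone, compound 3 gives > 20000 nM, a limit, and no step from compound 1 or compound 2 to compound 3 can be read. The compounds shown leave open at what concentration any of them stops being tolerated.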